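Notes on compound 4: shortened phosphate chain

This account rests on a few compounds, and the source may have more. Where it says the series, first, only, none or still open, it means among the compounds named here.

compound 1 `O=c1ccn([C@@H]2O[C@H](COP(=O)(O)OP(=O)(O)OP(=O)(O)O)[C@@H](O)[C@H]2O)c(=S)[nH]1` – 50 nM
compound 2 `Cc1cc(=O)n([C@@H]2O[C@H](COP(=O)(O)OP(=O)(O)OP(=O)(O)O)[C@@H](O)[C@H]2O)c(=O)[nH]1` – > 1000 nM (a limit)
compound 3 `CCCc1cc(=O)n([C@@H]2O[C@H](COP(=O)(O)OP(=O)(O)OP(=O)(O)O)[C@@H](O)[C@H]2O)c(=O)[nH]1` – > 1000 nM (a limit)

In an in vitro functional assay on 1321-N1 cells for agonist activity at P2Y purinoceptor 2 (Homo sapiens) (on this read-out higher numbers stand for an effect only at larger amounts of compound and lower numbers for an effect already at smaller amounts), compound 1 gives 50 nM. Compound 2 returns only a limit of the assay, > 1000 nM. Compound 3 likewise returns only a limit, > 1000 nM, and so stands at the limit of > 1000 nM in this assay, at which 2 of the 3 values shown sit, rather than at a number. Among the measured compounds shown here, the one readable step is an at least 20-fold higher number from compound 1 to compound 2 (1.30 log units; beyond the scatter); the step that the two limits leave unreadable from compound 2 to compound 3 cannot be read. Compound 4 `CCCc1cc(=O)n([C@@H]2O[C@H](COP(=O)(O)O)[C@@H](O)[C@H]2O)c(=O)[nH]1` differs from compound 3 by a hydrogen atom in place of a group of 8 heavy atoms (6 oxygen, 2 phosphorus; no ring), on an oxygen. Neither recorded step touches this part of the structure, so none bears on it. With compound 3 already at the limit, compound 4 is expected to stay at or beyond it, the step that the limit leaves unreadable from compound 3 to compound 4 being an estimate only. Compound 4 is estimated at 5000 nM (1000 nM to 50000 nM).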

Compound 4, half-maximal effective concentration: > 100000 nM
Compound 4 gave a limit, no number; the forecaster's own chance of this, stated with the estimate: 90%; middle value at least 20-fold (1.30 log units) away from the limit.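

Compound 3 and compound 4 both return only limits, not numbers, so no new step can be read between them. On these data alone, the size of any change from losing the 8-heavy-atom group on the oxygen remains open.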